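The compounds below may be only part of what the source reports. "The series", "measured", "known", "first", "only" and "open" are said of these compounds alone.

Measured so far in a functional assay on MDA-MB-231 cells (Homo sapiens) for antiproliferative activity, read by CCK-8 assay, with a stated time of 72 h; a higher number here means a weaker inhibitor, a lower number a stronger inhibitor:
compound 1 `Cc1ccc(C(=O)Nc2cccc(-c3oc4cc(-c5ccc(F)cc5)ccc4c(=O)c3O)c2)cc1` gives 4350 nM
compound 2 `O=C(Nc1cccc(-c2oc3cc(-c4ccc(F)cc4)ccc3c(=O)c2O)c1)c1cccc(F)c1` gives 2510 nM

Going by the values given here, compound 2 holds the lower of the two numbers, its only neighbour being a 1.7-fold lower number from compound 1 to compound 2 (0.24 log units; within the scatter), so the two are not separated beyond the scatter. Compound 3 `N#Cc1ccc(C(=O)Nc2cccc(-c3oc4cc(-c5ccc(F)cc5)ccc4c(=O)c3O)c2)cc1` carries the change (4-cyanophenyl in place of 3-fluorophenyl on a carbonyl carbon). Among the compounds with values here, the one measured step on this carbonyl carbon, a 1.7-fold lower number from compound 1 to compound 2 (0.24 log units; within the scatter), is small; it bears on the same position but swaps different groups, so it gives weak guidance. The expected step is a 1.2-fold higher number from compound 2 to compound 3 (0.08 log units; within the scatter), none beyond the scatter. Compound 3 is therefore estimated at 3000 nM, in the range 1200 nM to 8000 nM.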

Compound 3, half-maximal inhibitory concentration: 11600 nM
Estimate against measurement, compound 3: 3.9-fold (0.59 log units) below; the whole stated range lies below it.
By their numbers in this assay, from the lowest: compounds 2 and 1 (each within the scatter of the next); then compound 3.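

With a 4.6-fold higher number from compound 2 to compound 3 (0.66 log units; beyond the scatter) in this assay the group on this carbonyl carbon proves able to move the number beyond the scatter, which the earlier swap did not show. Going by these compounds alone, with a 2.7-fold higher number from compound 1 to compound 3 (0.43 log units; beyond the scatter) for cyano in place of methyl on an aromatic carbon, compound 3 stands apart from both of its neighbours, so 4-cyanophenyl is the one change here that goes with a weaker result. No measured evidence accounts for this step. Going by these compounds, whether the nitrile itself or any replacement at that ring carbon sets the loss stays open. An amine or a carboxylic acid there would help separate these readings.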